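The compounds below may be only part of what the source reports. "The series", "measured", "known", "first", "only" and "open" are said of these compounds alone.

In an ADME assay (liver) for metabolic stability, with Liver microsome (Rattus norvegicus) as the target, using microsomes and NADPH, with a stated time of 30 min, tested at 1 uM (a lower number here means slower removal, a higher number faster removal of the compound), compound 1 (`Nc1ccc(S(=O)(=O)N2CCN(c3ncc(C(O)(C(F)(F)F)C(F)(F)F)cc3C#CC3CC3)CC2)cn1`) gives 67 mL.min-1.g-1 and compound 2 (`Nc1ccc(S(=O)(=O)N2CCN(c3ncc(C(O)(C(F)(F)F)C(F)(F)F)cc3C#CCO)CC2)cn1`) gives 65 mL.min-1.g-1. Compound 3 (`CC(C)n1cc(-c2cc(C(O)(C(F)(F)F)C(F)(F)F)cnc2N2CCN(S(=O)(=O)c3ccc(N)nc3)CC2)cn1`) gives 198 mL.min-1.g-1, the highest of the three numbers. Compound 4 (`Nc1ccc(S(=O)(=O)N2CCN(c3ncc(C(O)(C(F)(F)F)C(F)(F)F)cc3-c3cccc(F)c3)CC2)cn1`) carries 3-fluorophenyl in place of 1-isopropyl-1H-pyrazol-4-yl on an aromatic carbon.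

Among the measured compounds shown here, no measured step exchanges one aromatic ring for another at this carbon, so the evidence is indirect. Putting 1-isopropyl-1H-pyrazol-4-yl in place of 2-cyclopropylethynyl gave a 3.0-fold higher number from compound 1 to compound 3 (0.47 log units; beyond the scatter), and putting it in place of 3-hydroxyprop-1-yn-1-yl gave a 3.0-fold higher number from compound 2 to compound 3 (0.48 log units; beyond the scatter). Only these two steps change the group on this carbon from a triple-bonded chain to a ring, and both go up. The remaining step, a 1.0-fold lower number from compound 1 to compound 2 (0.01 log units; within the scatter), shows no change beyond the scatter. Compound 4 keeps a ring on this carbon, so it is expected to stay nearer compound 3 than compound 1, with only a slight lean downward. The expected change is a 1.3-fold lower number from compound 3 to compound 4 (0.12 log units; within the scatter). Compound 4 is estimated at 150 mL.min-1.g-1, with an expected range of 75 mL.min-1.g-1 to 300 mL.min-1.g-1.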

Compound 4, intrinsic clearance in microsomes: 52 mL.min-1.g-1
Estimate against measurement, compound 4: 2.9-fold (0.46 log units) above; the whole stated range lies above it.
By their numbers in this assay, from the lowest: compounds 4, 2 and 1 (each within the scatter of the next); then compound 3.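

In this assay, a ring on this aromatic carbon does not by itself give the high number of compound 3: a 3.8-fold lower number from compound 3 to compound 4 (0.58 log units; beyond the scatter), with 3-fluorophenyl in place of 1-isopropyl-1H-pyrazol-4-yl, so the identity of the ring matters here. The change from a triple-bonded chain to a ring also no longer moves the number in one direction, as 3-fluorophenyl shows a 1.3-fold lower number from compound 2 to compound 4 (0.10 log units; within the scatter) and a 1.3-fold lower number from compound 1 to compound 4 (0.11 log units; within the scatter), leaving compound 3 alone beyond the scatter among these four compounds. Nothing available explains the difference between the two rings.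

The compounds shown do not separate the part played by the isopropyl group from that of the pyrazole ring, which a 1-methyl-1H-pyrazol-4-yl group on this carbon would address. From the compounds shown here alone, the part played by the fluorine also stays open, and an unsubstituted phenyl group would bear on it.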